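Swapping a nitrophenyl for a bromophenyl on a hydrazone

The source may report more compounds than this note shows. Statements on the series, on what has been measured and on what is new or still open speak of the compounds shown alone.

Of the compounds shown here, three sharing one core have been measured in a physicochemical assay for lipophilicity, measured as octanol-water partition; on this read-out higher numbers stand for higher lipophilicity and lower numbers for lower lipophilicity. Compound 1 `COc1ccc(/C=N/NC(=O)COc2cccc3ccccc23)cc1O` gives 3.48. Compound 2 `C/C(=N\NC(=O)COc1cccc2ccccc12)c1ccc([N+](=O)[O-])cc1` gives 3.37, the lowest of the three numbers. Compound 3 `O=C(COc1cccc2ccccc12)N/N=C/c1cccc(Br)c1` gives 4.81. Compound 2 lies nearest to compound 1, a gap that falls within the scatter of repeated measurements, so the two cannot be ordered; compound 3 stands well beyond the scatter above compound 2.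

Compound 4 `C/C(=N\NC(=O)COc1cccc2ccccc12)c1ccccc1Br` has not yet been measured in this assay. Its structure differs from compound 2 in a single place: 2-bromophenyl in place of 4-nitrophenyl on a carbon with a double bond to nitrogen. Among the measured compounds shown here, no measured pair in this set shows exactly this change, so the expected step has to be judged from the three numbers alone. For the measured compounds named here, compound 3, the only member carrying a bromophenyl, is the highest of the three, and the group that leaves compound 2 carries two hydrogen-bond acceptors while the group that enters carries none.

The step from compound 2 to compound 4 is therefore expected to be upward and beyond the scatter, an estimated a number 1.23 log units higher from compound 2 to compound 4 (beyond the scatter). Compound 4 is expected to give roughly 4.6 in this assay, within a range from 4.1 to 5.1.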

Compound 4, partition coefficient: 4.44
For compound 4 the middle estimate is 0.16 log units above the measured one; low and high end bracket the measured number.
By their numbers in this assay, from the lowest: compounds 2 and 1 (each within the scatter of the next); then compound 4; then compound 3.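

In this assay, among the compounds shown here, this is the first pair in the set that differs in one place only, so the effect of a single change at this position can finally be read. Placing 2-bromophenyl in place of 4-nitrophenyl on a carbon with a double bond to nitrogen gives a number 1.07 log units higher from compound 2 to compound 4 (beyond the scatter), a large step that shows the read-out is far from indifferent to what sits at this position. The change removes a group with 2 hydrogen-bond acceptors and brings in one with 0, but no measurement here explains the rise.

From the compounds shown here alone, this single step bundles several differences, so it remains open whether the rise comes from losing the nitro group, from gaining the bromine, or from where each sits on the phenyl ring. A plain phenyl on the same carbon would offer a common reference point for both groups, and an aminophenyl or a carboxylic acid there would show how far the read-out can move in the other direction.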